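The source may report more compounds than this note shows. Statements on the series, on what has been measured and on what is new or still open speak of the compounds shown alone.

Working notes on the sulfonyl series.

Three compounds carry a measurement in an assay on isolated protein for displacement of a labelled ligand from metabotropic glutamate receptor 5 (Homo sapiens), with a stated time of 60 min, tested at 1 uM; on this read-out higher numbers stand for more inhibition at the one concentration tested (going by the name of the read-out) and lower numbers for less inhibition. Compound 1 `COc1ccc2ncc(S(=O)(=O)c3ccc(OC)c(OC)c3)c(N3CCC(C)CC3)c2c1` gives -3%. Compound 2 `Cc1ccc(S(=O)(=O)c2cnc3ccc(F)cc3c2N2CCC(C)CC2)cc1Cl` gives 91%. Compound 3 `COc1ccc2ncc(S(=O)(=O)c3cc(C)cc(C)c3)c(N3CCC(C)CC3)c2c1` gives 79%.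

Compound 3 stands second highest of the three numbers: compound 2 lies above it by a step beyond the scatter, and compound 1 lies far below it. The single-place change a number 82 percentage points higher from compound 1 to compound 3 (beyond the scatter) shows that the aryl group on the sulfonyl sulfur carries most of the spread seen so far, with the 3,5-dimethylphenyl giving a large gain over the 3,4-dimethoxyphenyl.

Compound 4 `COc1ccc2ncc(S(=O)(=O)c3ccc(C)c(Cl)c3)c(N3CCC(C)CC3)c2c1` remains to be measured in this assay. It differs from compound 3 in one place: 3-chloro-4-methylphenyl in place of 3,5-dimethylphenyl on a sulfonyl sulfur. Among the compounds with values here, no measured step covers this exact exchange. Within the data shown here, the only related information is compound 2, which carries the same 3-chloro-4-methylphenyl on its sulfonyl sulfur, though on a differently substituted core, and gives 91%. Since both the 3,5-dimethylphenyl of compound 3 and the 3-chloro-4-methylphenyl of compound 2 sit at the high end of the numbers, the exchange is expected to give at most a small upward step, a number 6 percentage points higher from compound 3 to compound 4 (within the scatter), possibly none beyond the scatter. Compound 4 is therefore estimated at 85%, in the range 70% to 96%.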

Compound 4, a percentage reported as inhibition, at one concentration (the size of the read-out at that concentration, not a potency): 85%
The estimate for compound 4 equals the measured number at the digits printed; the range from low to high includes it.
By their numbers in this assay, from the lowest: compound 1; then compounds 3, 4 and 2 (each within the scatter of the next, the first and the last beyond it).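

In this assay, within the data shown here, a number 6 percentage points higher from compound 3 to compound 4 (within the scatter) shows that the 3-chloro-4-methylphenyl and the 3,5-dimethylphenyl on a sulfonyl sulfur cannot be told apart on the shared core, while a number 88 percentage points higher from compound 1 to compound 4 (beyond the scatter) gives a second large step away from the 3,4-dimethoxyphenyl, so the low number of compound 1 no longer rests on a comparison with a single aryl group. a number 6 percentage points lower from compound 2 to compound 4 (within the scatter) is the first reading at the other changed place, methoxy in place of fluoro on an aromatic carbon with the 3-chloro-4-methylphenyl held fixed, and this exchange does not separate the two compounds on this read-out. The compounds shown offer no measurement that accounts for any of these steps.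

Compounds 2, 3 and 4 all sit at the high end of a read-out taken at one concentration, so these numbers cannot show whether their potencies differ. From the compounds shown here alone, it remains open whether the large drop follows from the two methoxy groups together or from either one alone, and how a nitrile, a carboxylic acid or an amine on the aryl group on the sulfonyl sulfur would read.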